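The source may hold more compounds than are shown below. What is called first, only, known or untested is meant among the compounds shown, and "the series" means these compounds.

Of the compounds shown here, three of one series have so far been measured in a functional assay on the whole organism (Ear, strain Kunming) for inhibition, with Mus musculus as the target, with stated times of 1 h and 30 min, at a dose of 200 mg/kg by the oral route; on this read-out lower numbers stand for less inhibition and higher numbers for more inhibition at the one dose given (going by the name of the read-out). Compound 1 `Cc1ccc(/C=C2\CCCC(CN(C)c3ccccc3)C2=O)cc1` gives 39.5% in this assay. Going by the values given here, compound 2 `CN(CC1CCC/C(=C\c2ccc(S(C)(=O)=O)cc2)C1=O)c1ccccc1` gives 46.9%, and the single change between the two, methylsulfonyl in place of methyl on an aromatic carbon, amounts to a number 7.4 percentage points higher from compound 1 to compound 2 (within the scatter). Compound 3 `Cc1ccc(N(C)CC2CCC/C(=C\c3ccccc3)C2(O)c2ccccc2)cc1` gives 66.7%, the highest of the three numbers: compound 2 stands nearest, beyond the scatter below it, and compound 1 stands furthest, also beyond the scatter.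

Compound 4 `Cc1cccc(N(C)CC2CCC/C(=C\c3ccccc3)C2(O)c2ccccc2)c1` has not yet been measured in this assay. It differs from compound 3 in one place: 3-methylphenyl in place of 4-methylphenyl on an amine nitrogen. Among the compounds with values here, no measured step bears on this change. Within the data shown here, the only step at hand concerns a substituent on an aromatic carbon in another part of the molecule and is within the scatter, so it gives no guidance on an exchange at the amine nitrogen. Compound 3 is therefore the sole anchor, and the step from compound 3 to compound 4 in this assay is expected to be a number 4.7 percentage points lower from compound 3 to compound 4 (within the scatter), none beyond the scatter. Compound 4 is accordingly estimated at 62%, with a range from 45% to 78%.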

Compound 4, a percentage reported as inhibition, in the whole organism at one dose (the size of the read-out at that dose, not a potency): 23.1%
Estimate against measurement, compound 4: 38.9 percentage points above; measured number outside the range, below it.
By their numbers in this assay, from the lowest: compound 4; then compounds 1 and 2 (each within the scatter of the next); then compound 3.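

In this assay, moving the methyl group, with 3-methylphenyl in place of 4-methylphenyl on the amine nitrogen, gives a number 43.6 percentage points lower from compound 3 to compound 4 (beyond the scatter), although the two groups have the same atoms and the same counted features. Going by these compounds alone, the methyl group's place on this aromatic ring therefore matters greatly, which the earlier compounds could not show: their only step, a number 7.4 percentage points higher from compound 1 to compound 2 (within the scatter), concerned a different part of the molecule and a different kind of exchange. No measurement at hand accounts for the size of this drop, so the result stands as an observation without an explanation.

The compounds shown leave open whether the large gap belongs to the methyl group itself, since neither a plain phenyl on the amine nitrogen of this same core nor a methoxy group or a chlorine atom in place of that methyl appears among them. They also leave open whether the same exchange would have a similar effect on the core of compound 1, and, with only one dose in the read-out, how far this gap reflects a difference in potency.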